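The source may report more compounds than this note shows. Statements on the series, on what has been measured and on what is new or still open speak of the compounds shown alone.

Measured so far in an assay on membranes from CHO cells for displacement of a labelled ligand from adenosine receptor A1 (Homo sapiens), read by scintillation counting, with a stated time of 60 min, tested at 1 uM; a higher number here means more inhibition at the concentration tested (going by the name of the read-out), a lower number less inhibition:

- compound 1, `CCCOC(=O)C1=C(C)NC(=S)NC1c1ccoc1`: 4%
- compound 2, `CCCOC(=O)C1=C(C)NC(=S)NC1c1cccs1`: 7%
- compound 3, `CC1=C(c2ncc(C)o2)C(c2ccoc2)NC(=O)N1`: 21%

Compound 1 and compound 2 share one core; compound 3 and the unmeasured compound 4, `CC1=C(c2ncc(C)o2)C(c2cccs2)NC(=O)N1`, share another. The difference between the two cores is not broken down here. Within the first pair the change is thiophen-2-yl in place of furan-3-yl on a saturated ring carbon, and its step in this assay is a number 3 percentage points higher from compound 1 to compound 2 (within the scatter). Compound 3 holds the highest number of the three measured, and its gaps to compound 2 and to compound 1 are beyond the scatter.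

The change from compound 3 to compound 4 is thiophen-2-yl in place of furan-3-yl on a saturated ring carbon. Among the compounds with values here, it is the same kind of change as the one from compound 1 to compound 2, but the surroundings of the place differ: in the first pair the saturated ring carbon is next to the ring atom that bears a propoxycarbonyl group, in the second it is next to the ring atom that bears a 5-methyl-1,3-oxazol-2-yl group. Within the data shown here, only one instance of the change has been measured, so the expectation for compound 4 rests on that single step and on the value of compound 3.

Because a number 3 percentage points higher from compound 1 to compound 2 (within the scatter) lies within the scatter, the step from compound 3 to compound 4 is expected to be of similar size, a number 3 percentage points higher from compound 3 to compound 4 (within the scatter). Compound 4 is therefore estimated at 24% in this assay, with a likely range from 10% to 38%.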

Compound 4, a percentage reported as inhibition, at one concentration (the size of the read-out at that concentration, not a potency): 21%
Compound 4: middle estimate off by 3 percentage points, on the high side; low and high end bracket the measured number.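

In this assay, thiophen-2-yl in place of furan-3-yl on a saturated ring carbon gives no change at the digits printed from compound 3 to compound 4 (within the scatter). Set beside the earlier step, the change carries from one core to the other with no difference that can be read: the same change on two cores in this assay, a number 3 percentage points higher (within the scatter) from compound 1 to compound 2 and no change at the digits printed (within the scatter) from compound 3 to compound 4, 3 percentage points apart, within the scatter of two such steps This shows only that the exchange leaves no readable mark on either of these two cores at the single concentration tested; it does not show that the two rings are interchangeable on other cores, nor that their potencies match, since a percentage at one concentration is not a potency and two instances make a thin base.

Still open, from the compounds shown here alone, is what happens on the saturated ring carbon with a group of another kind, such as a phenyl ring, an amine or a longer chain, since only furan-3-yl and thiophen-2-yl appear there. Also open is how the 5-methyl-1,3-oxazol-2-yl group would compare with the propoxycarbonyl group or with a carboxylic acid on an otherwise identical core, as the two cores shown differ in more than one place and their difference cannot be divided among those places.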